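A few compounds are considered here, and "the series" means these few. Any claim that something is new, unique, unknown or untested is made for them only; others in the source may bear on it.

Working notes on the series. Compound 1 `COc1cc(-c2cc(-c3ccc(N)cc3)nc(-c3ccccc3)n2)cc(OC)c1OC` carries an amino group on the pendant aryl ring; in a functional assay on MDA-MB-231 cells (Homo sapiens) for inhibition, read by MTT assay, with a stated time of 48 h (a higher number here means a weaker inhibitor, a lower number a stronger inhibitor), compound 1 gives 1010 nM. Compound 2 `COc1cc(-c2cc(-c3ccc(Br)cc3)nc(-c3ccccc3)n2)cc(OC)c1OC` has bromo in place of amino, and in this assay compound 2 gives > 25000 nM, which is a limit of the assay and not a number. That value is the limit of > 25000 nM in this assay, at which 1 of the 3 values shown sits. Compound 3 `COc1ccc(-c2cc(-c3cc(OC)c(OC)c(OC)c3)nc(-c3ccccc3)n2)cc1` has methoxy in place of amino; in this assay compound 3 gives 3390 nM, the highest of the two actual numbers, with a 3.4-fold higher number from compound 1 to compound 3 (0.53 log units; beyond the scatter) and an at least 7.3-fold lower number from compound 2 to compound 3 (0.86 log units; beyond the scatter). The bromo swap gave an at least 24-fold higher number from compound 1 to compound 2 (1.39 log units; beyond the scatter).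

Compound 4 `COc1cc(-c2cc(-c3ccc(O)cc3)nc(-c3ccccc3)n2)cc(OC)c1OC` differs from compound 3 by hydrogen in place of methyl on an oxygen on an aromatic ring. Among the measured compounds shown here, no measured step alters this oxygen; the three measured steps exchange the whole substituent. A small step, possibly within the scatter, is expected, a 1.7-fold lower number from compound 3 to compound 4 (0.23 log units; within the scatter). The estimate for compound 4 is 2000 nM, range 700 nM to 6000 nM.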

Compound 4, half-maximal inhibitory concentration: 1600 nM
Estimate against measurement, compound 4: 1.3-fold (0.10 log units) above; the measured number falls inside the stated range.
By their numbers in this assay, from the lowest: compounds 1 and 4 (each within the scatter of the next); then compound 3. At a limit, above all of these: compound 2.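

On the 4-hydroxyphenyl ring, losing the methyl from the oxygen is a real change: a 2.1-fold lower number from compound 3 to compound 4 (0.33 log units; beyond the scatter). Hydroxy is the first group to match amino, since a 1.6-fold higher number from compound 1 to compound 4 (0.20 log units; within the scatter), so amino is not the only group at this place that gives a number in the range of compound 1. The step from bromo, an at least 15-fold lower number from compound 2 to compound 4 (1.19 log units; beyond the scatter), starts from a limit of the assay and not a number: the limit of > 25000 nM in this assay, at which 1 of the 4 values shown sits.

From the compounds shown here alone, what a carboxylic acid, a dimethylamino group or a fluoro group would give at this place remains open. Nothing shown separates hydroxy from amino here.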